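Methoxy added on the anilino ring of the benzylpiperazine urea

The compounds below may be only part of what the source reports. "The series", "measured", "known", "first", "only" and "open" are said of these compounds alone.

Compound 1 `COc1ccc(NC(=O)Nc2nc(Sc3c[nH]c4ccccc34)cc(N3CCN(c4ccccn4)CC3)n2)cc1`: 33400 nM
Compound 2 `O=C(Nc1ccccc1)Nc1nc(Sc2c[nH]c3ccccc23)cc(N2CCN(Cc3ccccc3)CC2)n1`: 42500 nM
Compound 3 `O=C(Nc1ccccc1)Nc1nc(Sc2c[nH]c3ccccc23)cc(N2CCN(c3ccccn3)CC2)n1`: 21600 nM

Three ureas sharing one core have been tested in a functional assay on PC-3 cells (Homo sapiens) for inhibition, with a stated time of 72 h; a higher number here means a weaker inhibitor, a lower number a stronger inhibitor. Compound 2 gives 42500 nM, the highest of the three numbers; compound 1 sits closest, and compound 3 furthest, yet the step of a 2.0-fold lower number from compound 2 to compound 3 (0.29 log units; within the scatter) stays within the scatter, as does the gap between compound 2 and compound 1. Compound 4 `COc1ccc(NC(=O)Nc2nc(Sc3c[nH]c4ccccc34)cc(N3CCN(Cc4ccccc4)CC3)n2)cc1` has not yet been measured. It differs from compound 2 in one place: methoxy in place of hydrogen on an aromatic carbon.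

One measured step speaks directly to this change, read in the opposite direction: a 1.5-fold lower number from compound 1 to compound 3 (0.19 log units; within the scatter). Removing the methoxy from compound 1 brought a lower number that did not leave the scatter, so putting it onto compound 2 is expected to bring a slightly higher number at most, if anything, in this assay. The change of the amine substituent, a 2.0-fold lower number from compound 2 to compound 3 (0.29 log units; within the scatter), does not touch the anilino ring and serves only to show that small changes around this core have so far moved the numbers little.

Compound 4 is therefore expected to give 55000 nM, with a range of 25000 nM to 120000 nM. The expected step of a 1.3-fold higher number from compound 2 to compound 4 (0.11 log units; within the scatter) is estimated to lie within the scatter.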

Compound 4, half-maximal inhibitory concentration: 16700 nM
Estimate against measurement, compound 4: 3.3-fold (0.52 log units) above, and the stated range ends above it.
By their numbers in this assay, from the lowest: compounds 4, 3, 1 and 2 (each within the scatter of the next, the first and the last beyond it).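

In this assay, methoxy in place of hydrogen on the six-membered aromatic ring of carbon only, para to a large group, brings a 2.5-fold lower number from compound 2 to compound 4 (0.41 log units; beyond the scatter), the first step around this core that lies beyond the scatter. The earlier compounds showed this change only with pyridin-2-yl on the amine nitrogen, and the two readings do not agree, so the effect of methoxy at this place depends on the group at the other end of the molecule: the same change on two cores in this assay, a 1.5-fold lower number (0.19 log units; within the scatter) from compound 1 to compound 3 and a 2.5-fold higher number (0.41 log units; beyond the scatter) from compound 4 to compound 2, 3.9-fold (0.59 log units) apart, beyond the scatter of two such steps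

The same coupling appears from the other side, where benzyl in place of pyridin-2-yl on the methoxy-bearing ureas gives a 2.0-fold lower number from compound 1 to compound 4 (0.30 log units; within the scatter), and the two places therefore cannot be read independently: the same change on two cores in this assay, a 2.0-fold lower number (0.29 log units; within the scatter) from compound 2 to compound 3 and a 2.0-fold higher number (0.30 log units; within the scatter) from compound 4 to compound 1, 3.9-fold (0.59 log units) apart, beyond the scatter of two such steps

The compounds shown carry only hydrogen or methoxy at this place, so it stays open whether an ethoxy, a hydroxy or a chloro group on the same carbon would behave like methoxy in compound 4. Also open, on these data alone, is whether the coupling extends to a third group on the amine nitrogen, such as methyl or acetyl, since only benzyl and pyridin-2-yl appear there.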